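A few compounds are considered here, and "the series" means these few. Any claim that something is new, unique, unknown or untested is made for them only; others in the source may bear on it.

Measured so far in a functional assay on HMEC-1 cells (Homo sapiens) for antiproliferative activity, read by cell counting, with a stated time of 4 days; a lower number here means a stronger inhibitor, a higher number a weaker inhibitor:

Compound 1, `CC(Nc1ccccc1Oc1ccc(Cl)cc1)=C1C(=O)CC(c2ccccc2)CC1=O`: 260 nM
Compound 2, `CC(Nc1ccccc1Oc1ccccc1)=C1C(=O)CC(c2ccccc2)CC1=O`: 160 nM

Going by the values given here, compound 2 has the lowest of the two numbers, but its only neighbour is compound 1, and the step of a 1.6-fold lower number from compound 1 to compound 2 (0.21 log units; within the scatter) lies within the scatter, so the two compounds cannot be told apart on these numbers. That step, hydrogen in place of chloro on an aromatic carbon, is the only one measured, and it concerns a different substituent on the phenoxy ring than the change now considered.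

Compound 3, `CC(Nc1ccccc1Oc1cccc(N)c1)=C1C(=O)CC(c2ccccc2)CC1=O`, is to be measured in this assay. It differs from compound 2 in one place: amino in place of hydrogen on an aromatic carbon. Among the compounds with values here, no measured step shows what an amino group at this place does, and the one step that touches the same ring was within the scatter. The expected step of a 1.3-fold higher number from compound 2 to compound 3 (0.10 log units; within the scatter) is therefore small, in no firm direction. Compound 3 is estimated at 200 nM, in the range 60 nM to 650 nM.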

Compound 3, half-maximal inhibitory concentration: 41 nM
Beside the measured number, compound 3's estimate is 4.9-fold (0.69 log units) above it; measured number below the stated range.
By their numbers in this assay, from the lowest: compound 3; then compounds 2 and 1 (each within the scatter of the next).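

In this assay, the earlier swap of chloro for hydrogen on the phenoxy ring left compounds 1 and 2 within the scatter, so it did not show whether changes on this ring could matter. Placing an amino group on an aromatic carbon of that ring, to give 3-aminophenoxy in place of phenoxy, does show this, with a 3.9-fold lower number from compound 2 to compound 3 (0.59 log units; beyond the scatter). Measured against the chlorinated compound, 3-aminophenyl in place of 4-chlorophenyl gives a 6.3-fold lower number from compound 1 to compound 3 (0.80 log units; beyond the scatter), which leaves compound 3 lowest of the three, with both its steps beyond the scatter.

Nothing available explains why the amino group has this effect. From the compounds shown here alone, it remains open whether the gain is specific to an amine, since a hydroxyl, methoxy or dimethylamino group at the same place, or an amino group elsewhere on the ring, could give a different number.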